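The source may hold more compounds than are shown below. What is called first, only, known or untested is meant among the compounds shown, and "the series" means these compounds.

Series notes. Compound 1 `C=CC1=C(C(=O)O)C(c2ccc(F)cc2)OC1` carries a 4-fluorophenyl group on the shared core; compound 2 `C=CC1=C(C(=O)O)C(c2ccc(OC)cc2)OC1` differs from it by methoxy in place of fluoro on an aromatic carbon. In a functional assay on SW480 cells (Homo sapiens) for cytotoxicity, read by MTT assay, with a stated time of 24 h (a lower number here means a stronger inhibitor, a higher number a weaker inhibitor), compound 1 gives > 100000 nM, which is a limit of the assay. In this assay compound 2 gives > 100000 nM, also a limit. The step that the two limits leave unreadable from compound 1 to compound 2 therefore cannot be sized, since the limit of > 100000 nM in this assay, at which 3 of the 3 values shown sit, covers both ends of it. Compound 3 `C=CC1=C(C(=O)NCc2ccc(OC)c(OC)c2)C(c2ccc(F)cc2)OC1` has a different core; the difference between the two cores is not broken down here. In this assay compound 3 gives > 100000 nM, again a limit. Compound 4 `C=CC1=C(C(=O)NCc2ccc(OC)c(OC)c2)C(c2ccc(OC)cc2)OC1` stands to compound 3 as compound 2 stands to compound 1: methoxy in place of fluoro on an aromatic carbon. The place is described in the same words for both pairs, with the added reading, cut one bond further out, of 4-fluorophenyl to 4-methoxyphenyl, so this is the same kind of change. For the measured compounds named here, because the limit of > 100000 nM in this assay, at which 3 of the 3 values shown sit, holds all three measured values, no step in this assay is readable and no direction for the change can be drawn. Compound 4 is expected to sit at the limit as well, a step that the limit leaves unreadable from compound 3 to compound 4. The estimate for compound 4 is 150000 nM, between 50000 nM and 500000 nM.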

Compound 4, half-maximal inhibitory concentration: 13500 nM
Estimate against measurement, compound 4: 11-fold (1.05 log units) above; measured number outside the range, below it.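

Going by these compounds, on the core of compound 3, methoxy in place of fluoro on an aromatic carbon gives an at least 7.4-fold lower number from compound 3 to compound 4 (0.86 log units; beyond the scatter) in this assay, so 4-fluorophenyl to 4-methoxyphenyl has a readable effect on this core, and its full size stays unknown since the value of compound 3 is a limit. On the core of compound 1 the same change cannot be read, and compound 2 gives > 100000 nM, which is also a limit. The series therefore shows no transfer of the change from one core to the other, neither a matching effect nor a differing one, and the single readable step rests on one pair: the limit of > 100000 nM in this assay, at which 3 of the 4 values shown sit.

On these data alone, whether the lower number in compound 4 is particular to methoxy, or also appears with a hydroxyl group or an amine on the same aromatic carbon, remains open. Also open, as far as these compounds go, is whether the step holds when a longer chain links the amide nitrogen to its aromatic ring.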